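A few compounds are considered here, and "the series" means these few. Any claim that something is new, unique, unknown or untested is made for them only; others in the source may bear on it.

Compound 1 `COc1cccc(-c2cc(C)c3ncc(CSCCc4ccccc4)n3c2)c1` shows, in an ADME assay on HEL cells (Homo sapiens) for cytotoxicity, with a stated time of 3 days (on this read-out higher numbers stand for lower toxicity in this test and lower numbers for higher toxicity in this test), a half-maximal cytotoxic concentration of 36 ug/mL. Compound 2 `Cc1cc(-c2ccsc2)cn2c(CSCCc3ccccc3)cnc12` differs from it by a thiophen-3-yl in place of the 3-methoxyphenyl on an aromatic carbon. For compound 2 this assay reports only a limit, > 50 ug/mL. The step of an at least 1.3-fold higher number from compound 1 to compound 2 (0.14 log units; that floor lies within the scatter) is therefore open-ended, and its floor is within the scatter, a consequence of the limit of > 50 ug/mL in this assay, at which 1 of the 2 values shown sits. So compound 2 stands at the limit of this test, not at a number.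

Compound 3 `COc1ccc(-c2cc(C)c3ncc(CSCCc4ccccc4)n3c2)cc1` arises from compound 2 by 4-methoxyphenyl in place of thiophen-3-yl on an aromatic carbon. Among the measured compounds shown here, only one measured step bears on this change, the one from compound 1 to compound 2, and it was small. By that account, compound 3 is expected to show no step beyond the scatter, with an estimated at least 1.2-fold lower number from compound 2 to compound 3 (0.09 log units; that floor lies within the scatter). The estimate for compound 3 is 40 ug/mL, between 20 ug/mL and 80 ug/mL.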

Compound 3, half-maximal cytotoxic concentration: 25.8 ug/mL
The estimate for compound 3 lay 1.6-fold (0.19 log units) above the measured number; measured number inside the range.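

Among the compounds shown here, with compound 3, this position has for the first time two aryl groups that can be compared by number on both sides: in this assay, 4-methoxyphenyl in place of 3-methoxyphenyl gives a 1.4-fold lower number from compound 1 to compound 3 (0.14 log units; within the scatter), so moving the methoxy group around the phenyl ring gives no readable change in this test. Against the thiophen-3-yl group, 4-methoxyphenyl gives an at least 1.9-fold lower number from compound 2 to compound 3 (0.28 log units; that floor lies within the scatter). That step is open-ended, and its floor alone shows no real difference: the limit of > 50 ug/mL in this assay, at which 1 of the 3 values shown sits.

On these data alone, whether thiophen-3-yl truly differs from either methoxyphenyl group therefore stays open. Also open is how this test would respond to an amine or a carboxylic acid on the ring at this position, as all three groups shown are neutral aromatic rings.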